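The compounds below may be only part of what the source reports. "The series", "measured", "known", "first", "only" and "open" are said of these compounds alone.

Among the measured compounds shown here, compound 1 `CCOC(=O)c1c(-c2cccc(C(F)(F)F)c2)csc1N` gives the highest of the three numbers measured so far: in an assay on CHO-K1 cells for displacement of a labelled ligand from adenosine receptor A1 (Homo sapiens), tested at 10 uM (on this read-out higher numbers stand for more inhibition at the one concentration tested (going by the name of the read-out) and lower numbers for less inhibition), compound 1 reaches 93%. Compound 2 `Nc1scc(-c2cccc(C(F)(F)F)c2)c1C(=O)c1ccccc1` gives 61.1% in this assay, and compound 3 `Nc1sc(-c2ccc([N+](=O)[O-])cc2)c(-c2cccc(C(F)(F)F)c2)c1C(=O)c1ccccc1` gives 34.8%. Two steps connect these three: a number 31.9 percentage points lower from compound 1 to compound 2 (beyond the scatter), and a number 26.3 percentage points lower from compound 2 to compound 3 (beyond the scatter). Compound 4 `CCOC(=O)c1c(N)sc(-c2ccccc2)c1-c1cccc(C(F)(F)F)c1` differs from compound 1 by phenyl in place of hydrogen on an aromatic carbon. The step from compound 2 to compound 3 is the closest measured model: it also put an aromatic ring onto an aromatic carbon of the core, and it lowered the number modestly. A drop of similar size is therefore expected here. Compound 4 is estimated at 68%, between 45% and 90%. That means an expected step of a number 25 percentage points lower from compound 1 to compound 4 (beyond the scatter).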

Compound 4, a percentage reported as inhibition, at one concentration (the size of the read-out at that concentration, not a potency): 83.6%
Estimate against measurement, compound 4: 15.6 percentage points below, and the stated range covers the measured number.
By their numbers in this assay, from the lowest: compound 3; then compound 2; then compounds 4 and 1 (each within the scatter of the next).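

On the aromatic carbon next to the ring sulfur, phenyl in place of hydrogen gives a number 9.4 percentage points lower from compound 1 to compound 4 (within the scatter) in this assay, so alongside the ethoxycarbonyl group this position accepts a whole aromatic ring without a step beyond the scatter. The earlier step at this position, with 4-nitrophenyl entering and phenyl on the carbonyl, was a number 26.3 percentage points lower from compound 2 to compound 3 (beyond the scatter), so an aromatic ring here does not always bring a clear drop. No measurement given here explains this difference. Still open, from the compounds shown here alone, is whether the nitro group or the group on the carbonyl separates these two steps, and how a phenyl ring carrying an amine or a simple methyl group would read here.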